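This account rests on a few compounds, and the source may have more. Where it says the series, first, only, none or still open, it means among the compounds named here.

Compound 1 `O=C1COc2ccc(-c3cccc(NS(=O)(=O)c4ccc(F)cc4)c3)cc2N1C1CC1` belongs to a small set tested in a functional assay on HCT-116 cells (Homo sapiens) for antiproliferative activity, read by MTT assay, with a stated time of 72 h; a lower number here means a stronger inhibitor, a higher number a weaker inhibitor. For compound 1 the reading is only a limit of the assay, > 40000 nM, not a number. Compound 2 `COc1ncc(-c2ccc3c(c2)N(C2CC2)C(=O)CO3)cc1NS(=O)(=O)c1ccc(F)cc1` gives 24300 nM in this assay. Compound 1 sits at the weak end of what is shown, its value being (the limit of > 40000 nM in this assay, at which 1 of the 2 values shown sits). Compound 3 `O=C1COc2ccc(-c3cccc(NS(=O)(=O)c4ccc(F)cc4)c3)cc2N1` differs from compound 1 by hydrogen in place of cyclopropyl on an amide-type nitrogen in a ring. For the measured compounds named here, no comparable pair has been measured, so the size of this step is unknown. The expected change a number no higher from compound 1 to compound 3 (the limit leaves the size open) is small, within the scatter. Compound 3 is expected to give about 40000 nM, between 15000 nM and 100000 nM.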

Compound 3, half-maximal inhibitory concentration: > 40000 nM
Compound 3: a limit, no number (the forecaster's own chance of this, stated with the estimate: 60%); the middle value lies on the limit itself.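

Compound 1 and compound 3 both give only a limit in this assay, and the step between them cannot be read. The compounds shown leave open what hydrogen in place of cyclopropyl does to activity.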